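A few compounds are considered here, and "the series" means these few. Any claim that something is new, unique, unknown or untested is made for them only; others in the source may bear on it.

Three compounds have been measured:
compound 1, `Fc1ccc(Nc2nccc(-c3ccncc3)n2)cc1`, 1900 nM
compound 2, `O=C(O)c1cc(=O)c2c(OCC(COc3cccc4oc(C(=O)O)cc(=O)c34)Oc3nccc(-c4ccccn4)n3)cccc2o1`, 1000000 nM
compound 3, `Cc1cccc(Nc2nccc(-c3ccccn3)n2)c1`, 700 nM

In a functional assay for inhibition, with Homo sapiens as the target (on this read-out lower numbers stand for stronger inhibition and higher numbers for weaker inhibition), compound 1 gives 1900 nM, the second highest of the three numbers. Compound 3 gives the lower number 700 nM, a gap beyond the usual scatter, while compound 2 gives 1000000 nM, far higher than either. The account now follows the step from compound 1 to compound 4, `CC(=O)N(C)c1ccc(Nc2nccc(-c3ccncc3)n2)cc1`, which has not yet been measured. The change is acetyl(methyl)amino in place of fluoro on an aromatic carbon. Going by the values given here, no measured pair carries this change, so in this assay only a modest step is expected, its direction open and quite possibly within the scatter. Compound 4 is therefore estimated at 2500 nM, between 600 nM and 10000 nM. The expected step is a 1.3-fold higher number from compound 1 to compound 4 (0.12 log units; within the scatter).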

Compound 4, half-maximal inhibitory concentration: 500 nM
Compound 4: middle estimate off by 5.0-fold (0.70 log units), on the high side, outside the stated range (below it).
By their numbers in this assay, from the lowest: compounds 4 and 3 (each within the scatter of the next); then compound 1; then compound 2.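

The step shows that this place, on an aromatic carbon para to a large group, accepts a much larger group than fluoro without loss: in this assay, acetyl(methyl)amino in its place gives a 3.8-fold lower number from compound 1 to compound 4 (0.58 log units; beyond the scatter). Going by these compounds alone, this is the first change at this place that can be read, and the larger group goes with the lower number. Nothing available explains the step.

From the compounds shown here alone, it remains open whether a plain amine, or an acetylamino group without the methyl, would give a similar number here.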